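From 3-nitrophenyl to 4-fluorophenyl in a cytotoxicity series

A few compounds are considered here, and "the series" means these few. Any claim that something is new, unique, unknown or untested is made for them only; others in the source may bear on it.

Results so far in a functional assay on A549 cells (Homo sapiens) for cytotoxicity, read by MTT assay, with a stated time of 72 h; on this read-out higher numbers stand for weaker inhibition and lower numbers for stronger inhibition
Compound 1 (`CNC(=O)c1cc(Oc2ccc(C3=NNC(c4cccc([N+](=O)[O-])c4)C3)cc2)ccn1`) gives "not determined" (no result reported)
Compound 2 (`CNC(=O)c1cc(Oc2ccc(C3=NNC(c4ccc(F)cc4)C3)cc2)ccn1`) gives 15100 nM
Compound 3 (`CNC(=O)c1cc(Oc2ccc(C3=NN(C(N)=S)C(c4cccc([N+](=O)[O-])c4)C3)cc2)ccn1`) gives > 50000 nM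

Compound 3 has only a limit, not a number (> 50000 nM). Compound 4 (`CNC(=O)c1cc(Oc2ccc(C3=NN(C(N)=S)C(c4ccc(F)cc4)C3)cc2)ccn1`) has 4-fluorophenyl in place of 3-nitrophenyl on a saturated ring carbon. Within the data shown here, no measured pair shows this change directly. Among the measured compounds shown here, a modest move towards stronger inhibition is nevertheless expected in this assay, with compound 2 as the only guide: compound 2, which also bears 4-fluorophenyl, gives 15100 nM in that test. The expected change is an at least 1.7-fold lower number from compound 3 to compound 4 (0.25 log units; that floor lies within the scatter) and remains uncertain. For compound 4 the estimated value is 28000 nM (expected range 10000 nM to 70000 nM).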

Compound 4, half-maximal inhibitory concentration: 19400 nM
For compound 4 the middle estimate is 1.4-fold (0.16 log units) above the measured one; the measured number falls inside the stated range.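

In this assay, among these compounds, 4-fluorophenyl in place of 3-nitrophenyl on the saturated ring carbon gives the first readable step at this position, an at least 2.5-fold lower number from compound 3 to compound 4 (0.41 log units; beyond the scatter). Compound 3 carries only a limit of the assay, so this step gives a floor and not a full size: the limit of > 50000 nM in this assay, at which 1 of the 4 values shown sits. With 4-fluorophenyl held in place, the group of 3 heavy atoms in place of a hydrogen atom on the amine nitrogen in the ring gives a 1.3-fold higher number from compound 2 to compound 4 (0.11 log units; within the scatter).

Going by these compounds, what a plain phenyl or a 4-aminophenyl would give on this ring carbon stays open.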